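The compounds below may be only part of what the source reports. "The series", "measured", "known", "first", "only" and "open" are said of these compounds alone.

In a functional assay on the whole organism (6C3HED cells, Mus musculus) for inhibition, at a dose of 300 mg/kg by the oral route (on this read-out lower numbers stand for less inhibition and higher numbers for more inhibition at the one dose given (going by the name of the read-out)), the measured compounds stand as follows:

Compound 1 `O=C(Nc1ccc(Cl)cc1)NS(=O)(=O)c1ccc(Cl)s1` gives 89%
Compound 2 `CSc1ccc(S(=O)(=O)NC(=O)Nc2ccc(Cl)cc2)s1` gives 62%
Compound 3 `CCOc1ccc(S(=O)(=O)NC(=O)Nc2ccc(Cl)cc2)s1` gives 96%

Compound 3 holds the highest of the three numbers; its gap to compound 1, a number 7 percentage points higher from compound 1 to compound 3 (within the scatter), lies within the scatter, while its gap to compound 2, a number 34 percentage points higher from compound 2 to compound 3 (beyond the scatter), is large and lies beyond it. Compound 4 `CC(C)c1ccc(S(=O)(=O)NC(=O)Nc2ccc(Cl)cc2)s1` differs from compound 3 by isopropyl in place of ethoxy on an aromatic carbon. Within the data shown here, no measured step replaces ethoxy with isopropyl, so only the steps at this same position bear on it: a number 27 percentage points lower from compound 1 to compound 2 (beyond the scatter) was modest, a number 7 percentage points higher from compound 1 to compound 3 (within the scatter) small, a number 34 percentage points higher from compound 2 to compound 3 (beyond the scatter) large. Varying this group has moved the read-out mostly downward from compound 3, so a drop of modest size is expected, a number 21 percentage points lower from compound 3 to compound 4 (beyond the scatter). Compound 4 is estimated at 75%, in a range from 45% to 95%.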

Compound 4, a percentage reported as inhibition, in the whole organism at one dose (the size of the read-out at that dose, not a potency): 63%
Compound 4: the middle estimate sits 12 percentage points above what was measured, and the stated range covers the measured number.
By their numbers in this assay, from the lowest: compounds 2 and 4 (each within the scatter of the next); then compounds 1 and 3 (each within the scatter of the next).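

Isopropyl in place of ethoxy gives a number 33 percentage points lower from compound 3 to compound 4 (beyond the scatter) in this assay and shows that a carbon group of the same heavy-atom count does not match ethoxy at this position. Isopropyl in place of methylsulfanyl gives a number 1 percentage points higher from compound 2 to compound 4 (within the scatter) and isopropyl in place of chloro gives a number 26 percentage points lower from compound 1 to compound 4 (beyond the scatter) so the four groups fall into two sets, chloro with ethoxy and methylsulfanyl with isopropyl. Nothing available here accounts for this split.

Which set an amine or a longer alkoxy chain such as butoxy would join stays open.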